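Lengthening the Chain Again: Compound 2 to Compound 3

A few compounds are considered here, and "the series" means these few. Any claim that something is new, unique, unknown or untested is made for them only; others in the source may bear on it.

- compound 1 `C#C[C@H](O)/C=C/CCCCC/C=C\CCCC/C=C\CCCCCCCCC/C=C/[C@@H](O)C#C` gives 160 nM
- compound 2 `C#C[C@H](O)/C=C/CCCCCCC/C=C\CCCC/C=C\CCCCCCCCC/C=C/[C@@H](O)C#C` gives 160 nM

In a functional assay on HCT-8 cells (Homo sapiens) for cytotoxicity (on this read-out higher numbers stand for weaker inhibition and lower numbers for stronger inhibition), compound 1 and compound 2 stand level, with compound 2 reading 160 nM. Compound 3 `C#C[C@H](O)/C=C/CCCCCCCCC/C=C\CCCC/C=C\CCCCCCCCC/C=C/[C@@H](O)C#C` has not been measured, and it differs from compound 2 by a group of 8 heavy atoms (7 carbon, 1 oxygen; no ring) in place of a group of 6 heavy atoms (5 carbon, 1 oxygen; no ring), on a saturated chain carbon, seven bonds along the chain from a double-bonded chain carbon. Among the compounds with values here, only one measured step bears on this, the same swap made five bonds along the chain rather than seven, and it gave no change at the digits printed from compound 1 to compound 2 (within the scatter). A single step is thin evidence, but it points to no change beyond the scatter in this assay. The expected step is no change at the digits printed from compound 2 to compound 3 (within the scatter). For compound 3 the estimate is 160 nM, with an expected range from 70 nM to 380 nM.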

Compound 3, half-maximal inhibitory concentration: 160 nM
For compound 3 middle estimate and measured number coincide at the digits printed, within the range that was stated.
By their numbers in this assay, from the lowest: compounds 1, 2 and 3 (each within the scatter of the next).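

In this assay, the same swap made seven bonds along the chain, rather than five, gives no change at the digits printed from compound 2 to compound 3 (within the scatter). Across both swaps together, a group of 10 heavy atoms in place of a group of 6 gives no change at the digits printed from compound 1 to compound 3 (within the scatter), so this stretch of saturated chain tolerates added length at both places tested. No measurement offered here explains this lack of response.

From the compounds shown here alone, whether a still longer chain would hold the same level remains open. So does the effect of an amine or a carboxylic acid placed on this chain.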